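Triazolyl phthalimide sulfides: cytotoxicity series, ester variant

A few compounds are considered here, and "the series" means these few. Any claim that something is new, unique, unknown or untested is made for them only; others in the source may bear on it.

Measured so far:
Compound 1 `Cc1nnc(SCc2ccccc2)n1N1C(=O)c2ccccc2C1=O`: in a functional assay on A549 cells (Homo sapiens) for cytotoxicity, read by MTT assay, with a stated time of 48 h (on this read-out higher numbers stand for weaker inhibition and lower numbers for stronger inhibition), compound 1 gives > 200000 nM, a limit of the assay.
Compound 2 `CSc1nnc(C)n1N1C(=O)c2ccccc2C1=O`: in this assay compound 2 gives > 200000 nM, a limit.
Compound 3 `CCc1nnc(SCc2ccccc2)n1N1C(=O)c2ccccc2C1=O`: in this assay compound 3 gives > 200000 nM, a limit.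

Compound 3 stands only at a limit, with no number behind it; the same holds for every value shown, as all three sit at the limit of > 200000 nM in this assay, at which 3 of the 3 values shown sit.

Compound 4 `CCOC(=O)CSc1nnc(CC)n1N1C(=O)c2ccccc2C1=O` is not yet measured. Its difference from compound 3 is ethoxycarbonyl in place of phenyl on a saturated chain carbon bound to a sulfur.

For the measured compounds named here, two measured steps touch this series. The step that the two limits leave unreadable from compound 1 to compound 2 alters the same place, a saturated chain carbon bound to a sulfur, and its size is unreadable. The step that the two limits leave unreadable from compound 1 to compound 3 lies elsewhere and is likewise unreadable. No readable step is available, so no direction can be drawn from the measured compounds.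

On that basis compound 4 is expected to sit again at the limit, estimated as 200000 nM with a range from 100000 nM to 400000 nM. The expected step is a number no higher from compound 3 to compound 4 (the limit leaves the size open), not readable beyond the scatter.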

Compound 4, half-maximal inhibitory concentration: > 200000 nM
Compound 4: a limit, no number; the forecaster's own chance of this, stated with the estimate: 85%; the middle value lies on the limit itself.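

In this assay no step can be read from compound 3 to compound 4, as both stand at a limit: the limit of > 200000 nM in this assay, at which 4 of the 4 values shown sit.

The compounds shown leave open whether any change on the shared core, including at the saturated chain carbon bound to a sulfur, would bring cytotoxicity to a measurable number.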